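The source may hold more compounds than are shown below. What is called first, only, known or untested is meant among the compounds shown, and "the series" means these compounds.

The measured compounds, with their values in a functional assay on MCF7 cells (Homo sapiens) for antiproliferative activity, read by MTT assay, with a stated time of 72 h; a lower number here means a stronger inhibitor, a higher number a weaker inhibitor: compound 1 `CC(C)(C)c1cn(C[C@H](O)[C@H]2OC(=O)C(OCc3ccccc3)=C2OCc2ccccc2)nn1` gives 730 nM; compound 2 `O=C1O[C@H]([C@@H](O)Cn2cc(CCO)nn2)C(OCc2ccccc2)=C1OCc1ccccc1` gives 63400 nM. Compound 3 `COc1ccccc1-c1cn(C[C@H](O)[C@H]2OC(=O)C(OCc3ccccc3)=C2OCc2ccccc2)nn1` reaches only the limit of the assay, > 100000 nM.

Compound 3 thus stands at the top of the three, at the limit of > 100000 nM in this assay, at which 1 of the 3 values shown sits, and its steps are floors: an at least 130-fold higher number from compound 1 to compound 3 (2.13 log units; beyond the scatter), and an at least 1.5-fold higher number from compound 2 to compound 3 (0.19 log units; that floor lies within the scatter). Compound 4 `O=C1O[C@H]([C@@H](O)Cn2ccnn2)C(OCc2ccccc2)=C1OCc1ccccc1` differs from compound 3 by hydrogen in place of 2-methoxyphenyl on an aromatic carbon. Going by the values given here, no measured step replaces a group with hydrogen. The nearest comparison is an 87-fold higher number from compound 1 to compound 2 (1.94 log units; beyond the scatter), which shows that a change at this carbon moves the number widely. A large step is therefore expected in this assay, most likely downward. Compound 4 is expected at 30000 nM, between 5000 nM and 150000 nM. This amounts to an expected step of an at least 3.3-fold lower number from compound 3 to compound 4 (0.52 log units; beyond the scatter).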

Compound 4, half-maximal inhibitory concentration: > 100000 nM
Compound 4: a limit, no number; the forecaster's own chance of this, stated with the estimate: 30%; at least 3.3-fold (0.52 log units) between middle value and limit.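

In this assay compound 4 gives a limit, not a number, and it is the second compound to do so: the limit of > 100000 nM in this assay, at which 2 of the 4 values shown sit.

Hydrogen on this aromatic carbon does not hold the level seen with tert-butyl, with an at least 130-fold higher number from compound 1 to compound 4 (2.13 log units; beyond the scatter). Against 2-hydroxyethyl there is only an at least 1.5-fold higher number from compound 2 to compound 4 (0.19 log units; that floor lies within the scatter), and the step between compound 3 and compound 4 cannot be read, as both values are limits.

The compounds shown leave open whether an isopropyl or a cyclohexyl group on this carbon would stay near compound 1. They also leave open how far compound 4 truly lies from compound 2.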